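The source may report more compounds than this note shows. Statements on the series, on what has been measured and on what is new or still open speak of the compounds shown alone.

Compound 1 `C#CCSc1nnc(-c2cc(OC)c(OC)c(OC)c2)n1N1C(=O)c2ccccc2C1=O` — in a functional assay on PC-3M cells (Homo sapiens) for cytotoxicity, read by MTT assay, with a stated time of 48 h (on this read-out lower numbers stand for stronger inhibition and higher numbers for weaker inhibition), compound 1 gives > 200000 nM
Compound 2 `COc1cc(-c2nnc(SCc3ccccc3)n2N2C(=O)c3ccccc3C2=O)cc(OC)c1OC` — in this assay compound 2 gives > 200000 nM

The value of compound 2 is a limit of this assay, not a measured number. For the measured compounds named here, the only measured step, a step that the two limits leave unreadable from compound 1 to compound 2, therefore cannot be read in size or direction. Every result so far rests at the limit of > 200000 nM in this assay, at which 2 of the 2 values shown sit, so compound 2 stands at the top end of what this assay can report, with no number to compare.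

Compound 3 `COc1cc(-c2nnc(SCC(=O)c3ccc(F)cc3)n2N2C(=O)c3ccccc3C2=O)cc(OC)c1OC` differs from compound 2 by (4-fluorophenyl)carbonyl in place of phenyl on a saturated chain carbon bound to a sulfur. Going by the values given here, no measured step bears on this change, since the one step known is unreadable and both measured compounds sit at the limit. With nothing pointing toward a gain, compound 3 is expected to remain near the limit, and the step of a number no higher from compound 2 to compound 3 (the limit leaves the size open) is estimated as none beyond the scatter. Compound 3 is estimated at 200000 nM, within 40000 nM to 1000000 nM.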

Compound 3, half-maximal inhibitory concentration: > 200000 nM
Compound 3 was reported as a limit; the forecaster's own chance of this, stated with the estimate: 80%; the middle value lies on the limit itself.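

In this assay compound 3 gives > 200000 nM, which is a limit and not a number. The steps joining compound 1, compound 2 and compound 3 therefore cannot be read. The compounds shown leave open whether any group on the saturated chain carbon bound to a sulfur changes cytotoxicity at all, as all results sit at one point: the limit of > 200000 nM in this assay, at which 3 of the 3 values shown sit.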